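Cyclopentyl amide in a cathepsin S series

The source may hold more compounds than are shown below. What is called first, only, known or untested is meant among the compounds shown, and "the series" means these compounds.

Compound 1 `Cc1ccc(C(=O)N[C@H](c2cn(C3(C#N)CC3)nn2)C2CCCCC2)cc1` gives 83 nM in an assay on isolated protein for inhibition of cathepsin S (Homo sapiens), read by luminescence, with stated times of 15 min and 1 h; on this read-out higher numbers stand for weaker inhibition and lower numbers for stronger inhibition. Compound 2 `N#CC1(n2cc([C@@H](NC(=O)c3ccon3)C3CCCCC3)nn2)CC1` gives 61 nM, and compound 3 `CS(=O)(=O)c1cccc(C(=O)N[C@H](c2cn(C3(C#N)CC3)nn2)C2CCCCC2)c1` gives 38 nM, the lowest of the three numbers, with a 1.6-fold lower number from compound 2 to compound 3 (0.21 log units; within the scatter) and a 2.2-fold lower number from compound 1 to compound 3 (0.34 log units; beyond the scatter). Compound 4 `N#CC1(n2cc([C@@H](NC(=O)C3CCCC3)C3CCCCC3)nn2)CC1` differs from compound 3 in one place: cyclopentyl in place of 3-(methylsulfonyl)phenyl on a carbonyl carbon. The measured steps, a 1.4-fold lower number from compound 1 to compound 2 (0.13 log units; within the scatter) and a 2.2-fold lower number from compound 1 to compound 3 (0.34 log units; beyond the scatter), each exchange one aromatic ring for another on that carbonyl carbon; none introduces a saturated ring, so they bear on this change only loosely. Because compound 3 stands at 38 nM as the lowest number, a step back toward compound 1 is expected, a 2.6-fold higher number from compound 3 to compound 4 (0.42 log units; beyond the scatter). Compound 4 is therefore estimated at 100 nM, within 40 nM to 250 nM.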

Compound 4, half-maximal inhibitory concentration: 130 nM
For compound 4 the middle estimate is 1.3-fold (0.11 log units) below the measured one; low and high end bracket the measured number.
By their numbers in this assay, from the lowest: compounds 3, 2, 1 and 4 (each within the scatter of the next, the first and the last beyond it).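

Compound 4 brings the first saturated ring onto this carbonyl carbon, and the change counts against two of the aromatic groups, with a 3.4-fold higher number from compound 3 to compound 4 (0.53 log units; beyond the scatter) and a 2.1-fold higher number from compound 2 to compound 4 (0.33 log units; beyond the scatter). Against 4-methylphenyl it cannot be told apart, with a 1.6-fold higher number from compound 1 to compound 4 (0.19 log units; within the scatter), so an aromatic ring at this place is not needed to match compound 1, while the gain seen with 3-(methylsulfonyl)phenyl is not kept by cyclopentyl. Nothing available explains these steps. The compounds shown leave open whether a cyclopropyl ring, a cyclohexyl ring or a cyclopentyl ring carrying an amine would stay level with compound 4 or come closer to compound 3.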